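Swapping phenyl for methyl on the ring nitrogen

A few compounds are considered here, and "the series" means these few. Any claim that something is new, unique, unknown or untested is made for them only; others in the source may bear on it.

Measured in an assay for displacement of a labelled ligand from Sigma non-opioid intracellular receptor 1 (Cavia porcellus), read by scintillation counting, with a stated time of 180 min; a lower number here means a stronger inhibitor, a higher number a weaker inhibitor:
compound 1 `CCCN1CCC2(CC1)OC(OC)Cc1c2cnn1-c1ccccc1` gives 33 nM
compound 2 `CCCN1CCC2(CC1)OC(OC)Cc1c2cnn1C` gives > 1000 nM
compound 3 `c1ccc(CN2CCC3(CC2)OCCc2c3cnn2-c2ccccc2)cc1` gives 1.71 nM

The value of compound 2 is a limit of this assay, not a number. Of the two numbers, compound 3 has the lower one, and the gap to compound 1 lies beyond the usual scatter; the difference between the core of compound 3 and the core of compound 1 is not broken down here.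

Compound 1 and compound 2 differ in a single place: methyl in place of phenyl on an aromatic nitrogen. This change produced an at least 30-fold higher number from compound 1 to compound 2 (1.48 log units; beyond the scatter), and the step is known only as a lower bound because compound 2 sits at the limit of > 1000 nM in this assay, at which 1 of the 3 values shown sits.

Compound 4 `Cn1ncc2c1CCOC21CCN(Cc2ccccc2)CC1` has not yet been measured in this assay. It differs from compound 3 by methyl in place of phenyl on an aromatic nitrogen, the same change that separates compound 1 from compound 2, made on the core of compound 3 instead. Since that change once gave an at least 30-fold higher number from compound 1 to compound 2 (1.48 log units; beyond the scatter), compound 4 is expected to show a large weakening as well, estimated as a 58-fold higher number from compound 3 to compound 4 (1.77 log units; beyond the scatter). Starting from compound 3 and its 1.71 nM, the expected value for compound 4 is about 100 nM, most likely between 30 nM and 600 nM. There is also some chance that this assay reports only a limit for compound 4.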

Compound 4, inhibition constant: 9.2 nM
Beside the measured number, compound 4's estimate is 11-fold (1.04 log units) above it; the whole stated range lies above it.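

In this assay, putting methyl in place of phenyl on the aromatic nitrogen weakens binding on both cores, and on the core of compound 3 it gives a 5.4-fold higher number from compound 3 to compound 4 (0.73 log units; beyond the scatter), but the size of the loss does not carry over unchanged: the same change on two cores in this assay, an at least 30-fold higher number (1.48 log units; beyond the scatter) from compound 1 to compound 2 and a 5.4-fold higher number (0.73 log units; beyond the scatter) from compound 3 to compound 4, at least 5.6-fold (0.75 log units) apart, beyond the scatter of two such steps. So the direction of the change held on these two cores, while the size of the step on one core was a poor guide to its size on the other. On these data alone, this does not show how much of the gap comes from any one difference between the two cores, and the full size of the first step remains unknown, as the value of compound 2 is a limit and not a number: the limit of > 1000 nM in this assay, at which 1 of the 4 values shown sits.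

The compounds shown leave open which difference between the cores matters, the propyl or benzyl group on the other ring nitrogen or the methoxy group on the oxygen-containing ring. They also leave open how groups other than phenyl and methyl on the aromatic nitrogen would behave, such as a longer chain like butyl or a saturated ring like cyclohexyl.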